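This account rests on a few compounds, and the source may have more. Where it says the series, first, only, none or still open, it means among the compounds named here.

Measured compounds:
- Compound 1, `OB1OCc2ccc(-n3cc(Sc4ccc(Cl)c(Cl)c4)c4ccccc43)cc21`. In an ADME assay on L929 cells (Mus musculus) for cytotoxicity, read by resazurin assay, with a stated time of 72 h (a higher number here means a weaker inhibitor, a lower number a stronger inhibitor), compound 1 gives > 10 ug/mL, which is a limit of the assay.
- Compound 2, `CCCNC(=O)c1cccn1-c1ccc2c(c1)B(O)OC2`. In this assay compound 2 gives > 10 ug/mL, again a limit of the assay.
- Compound 3, `O=C(c1ccccc1)c1ccn(-c2ccc3c(c2)B(O)OC3)c1`. In this assay compound 3 gives > 10 ug/mL, once more a limit of the assay.

Compound 3 therefore stands where every measured member of the series stands: at the limit and without a number of its own. For the measured compounds named here, no step between measured compounds is available, and the three values show only that none of them reached a half-maximal inhibitory concentration inside the range of this assay (the limit of > 10 ug/mL in this assay, at which 3 of the 3 values shown sit).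

The next compound is compound 4, `O=C(c1ccc(Cl)cc1)c1ccn(-c2ccc3c(c2)B(O)OC3)c1`. It differs from compound 3 by chloro in place of hydrogen on an aromatic carbon.

Going by the values given here, with no measured step to lean on, the expectation for compound 4 in this assay is a step of no size beyond the scatter, in no particular direction, and most likely another limit. Compound 4 is thus estimated at 10 ug/mL, with a range from 5 ug/mL to 30 ug/mL. The expected step from compound 3 to compound 4 is a number no higher from compound 3 to compound 4 (the limit leaves the size open), which is to say that a number, if one is reported at all, is expected close to where compound 3 sits.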

Compound 4, half-maximal inhibitory concentration: > 10 ug/mL
Compound 4 was reported as a limit; the forecaster's own chance of this, stated with the estimate: 80%; the middle value lies on the limit itself.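

In this assay compound 4 gives > 10 ug/mL as a limit of the assay. No step can be read between compound 3 and compound 4, as both stand at a limit: the limit of > 10 ug/mL in this assay, at which 4 of the 4 values shown sit. The compounds shown leave open where any of them would reach a half-maximal inhibitory concentration in this assay and whether chloro in place of hydrogen would shift it.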